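The source may report more compounds than this note shows. Statements on the series, on what has been measured and on what is new or still open speak of the compounds shown alone.

The measured compounds:
Compound 1 `COc1ccc(-c2nc(C(F)(F)F)n(CC[C@@H](O)C[C@@H](O)CC(=O)O)c2-c2ccc(F)cc2)cc1` gives 68 nM in an assay on microsomes from liver for inhibition of 3-hydroxy-3-methylglutaryl-coenzyme A reductase (Rattus norvegicus); a lower number here means a stronger inhibitor, a higher number a weaker inhibitor.
Compound 2 `Cc1cc(-c2nc(C(F)(F)F)n(CC[C@@H](O)C[C@@H](O)CC(=O)O)c2-c2ccc(F)cc2)cc(C)c1F` gives 32 nM in this assay.

Among these two numbers compound 2 stands lowest; its only neighbour is compound 1, and the step of a 2.1-fold lower number from compound 1 to compound 2 (0.33 log units; beyond the scatter) lies beyond the scatter.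

Compound 3 `O=C(O)C[C@H](O)C[C@H](O)CCn1c(C(F)(F)F)nc(-c2cccnc2)c1-c1ccc(F)cc1` has not yet been measured in this assay. It differs from compound 2 at a single place: pyridin-3-yl in place of 4-fluoro-3,5-dimethylphenyl on an aromatic carbon. Within the data shown here, the one measured step that touches this position is a 2.1-fold lower number from compound 1 to compound 2 (0.33 log units; beyond the scatter), a modest change when one six-membered carbon ring replaced another at the same place. Among the measured compounds shown here, no measured compound carries pyridin-3-yl, so nothing shows directly how this group behaves here; the single step only shows that this position moves the number modestly. The expectation is therefore a modest step, a 1.7-fold higher number from compound 2 to compound 3 (0.24 log units; within the scatter), more likely toward a higher number than a lower one, with compound 2 already standing at the lowest of the two measured values. For compound 3 the estimate in this assay is 55 nM, within a range from 20 nM to 150 nM.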

Compound 3, half-maximal inhibitory concentration: 66 nM
Compound 3: the middle estimate sits 1.2-fold (0.08 log units) below what was measured, and the stated range covers the measured number.
By their numbers in this assay, from the lowest: compound 2; then compounds 3 and 1 (each within the scatter of the next).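

In this assay, pyridin-3-yl, with a nitrogen in the ring and fewer heavy atoms than 4-fluoro-3,5-dimethylphenyl, gives a 2.1-fold higher number from compound 2 to compound 3 (0.31 log units; beyond the scatter) and so shows that a ring with a hetero atom can stand at this position with only a modest change in the number. Set against 4-methoxyphenyl, the same group gives a 1.0-fold lower number from compound 1 to compound 3 (0.01 log units; within the scatter) and leaves those two compounds indistinguishable in this measurement, so among the three groups only the 4-fluoro-3,5-dimethylphenyl of compound 2 stands apart, by steps beyond the scatter to both others. No measurement of any property of these groups is available to bear on this result.

The compounds shown leave open whether the two methyl groups, the fluorine or both together separate compound 2 from the others, a question that 3,5-dimethylphenyl and 4-fluorophenyl at this position would address. They also leave open how pyridin-4-yl, a ring carrying an amine or a saturated cyclohexyl ring would behave at the same place.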